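Longer thioether chains on the chloromethyl ketone core

The compounds below may be only part of what the source reports. "The series", "measured", "known", "first", "only" and "open" are said of these compounds alone.

Measured in a functional assay on NALM-6 cells (Homo sapiens); on this read-out lower numbers stand for stronger inhibition and higher numbers for weaker inhibition:
compound 1 `CCCSC[C@H](NC(C)=O)C(=O)CCl`: 6900 nM
compound 2 `CCCCSC[C@H](NC(C)=O)C(=O)CCl`: 41400 nM
compound 3 `CCCCCCCCCCSC[C@H](NC(C)=O)C(=O)CCl`: 4700 nM

Compound 3 stands at the low end of the three numbers, but its gap to compound 1 lies within the scatter; only compound 2 is clearly apart. Compound 4 `CCCCCCCCCCCCCCCCSC[C@H](NC(C)=O)C(=O)CCl` differs from compound 3 by hexyl in place of hydrogen on a saturated chain carbon, ten or more bonds along the chain from a sulfur. Among the measured compounds shown here, two measured steps bear on lengthening this chain: a 1.5-fold lower number from compound 1 to compound 3 (0.17 log units; within the scatter), and an 8.8-fold lower number from compound 2 to compound 3 (0.94 log units; beyond the scatter). From the compounds shown here alone, neither measured pair reaches beyond a decyl chain, so the further extension is untested. Compound 4 is therefore expected to stay close to compound 3, with an estimated step of a 1.2-fold lower number from compound 3 to compound 4 (0.07 log units; within the scatter). In this assay compound 4 is estimated at 4000 nM, with a range from 1500 nM to 12000 nM.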

Compound 4, half-maximal inhibitory concentration: 16000 nM
Beside the measured number, compound 4's estimate is 4.0-fold (0.60 log units) below it; the whole stated range lies below it.
By their numbers in this assay, from the lowest: compounds 3 and 1 (each within the scatter of the next); then compound 4; then compound 2.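

Adding hexyl at this far end of the chain no longer leaves the number level in this assay (a 3.4-fold higher number from compound 3 to compound 4 (0.53 log units; beyond the scatter)), so lengthening has a limit here. With the earlier fall (an 8.8-fold lower number from compound 2 to compound 3 (0.94 log units; beyond the scatter)), the series shows no steady trend with chain length, and compound 2 and compound 4 both go against any reading that longer is better. Nothing on hand accounts for this rise. A dodecyl chain would show how sharply the number turns upward, and a chain carrying an amine or a carboxylic acid remains an open case.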